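Adding a methoxy to the phenoxy group of compound 2

The source may hold more compounds than are shown below. What is called first, only, known or untested is meant among the compounds shown, and "the series" means these compounds.

Of the compounds shown here, two have been measured so far. Compound 1 `COc1cccc(-c2ccc([C@H]3S[C@@H](C)C(=O)Nc4c3c(C)nn4-c3ccccc3C)cc2)c1` gives 41% in an assay on isolated protein for agonist activity at Bile acid receptor (Homo sapiens), read by AlphaScreen, with a stated time of 30 min (on this read-out lower numbers stand for smaller maximal responses and higher numbers for larger maximal responses), and compound 2 `Cc1ccccc1-n1nc(C)c2c1NC(=O)[C@H](C)S[C@@H]2c1ccc(Oc2ccccc2)cc1` gives 118%. Compound 2 stands highest of the two, because the change a number 77 percentage points higher from compound 1 to compound 2 (beyond the scatter) was large. Compound 3 `COc1ccccc1Oc1ccc([C@H]2S[C@@H](C)C(=O)Nc3c2c(C)nn3-c2ccccc2C)cc1` differs from compound 2 by methoxy in place of hydrogen on an aromatic carbon. Among the compounds with values here, no measured step shows the same change, since the only step on record swaps one whole aromatic substituent for another rather than adding a small group to one that is already there, so it cannot say what adding a methoxy to the phenoxy group will do. With nothing pointing either way, a step within the scatter is expected, which is a number 13 percentage points lower from compound 2 to compound 3 (beyond the scatter). Compound 3 is therefore estimated to give 105%, with a likely range from 65% to 135%.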

Compound 3, largest response reached (reported as efficacy), in percent of the reference or control that the assay uses: 240%
The estimate for compound 3 lay 135 percentage points below the measured number; measured number above the stated range.
By their numbers in this assay, from the lowest: compound 1; then compound 2; then compound 3.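

In this assay, a methoxy in place of hydrogen, on an aromatic carbon ortho to a large group, gives a number 122 percentage points higher from compound 2 to compound 3 (beyond the scatter) and so shows that a change of just 2 heavy atoms on the phenoxy group can move the maximal response strongly. The swap of 3-methoxyphenyl for 2-methoxyphenoxy gives a number 199 percentage points higher from compound 1 to compound 3 (beyond the scatter) but alters the link to the core and the place of the methoxy together, so that step alone cannot separate the two changes. Nothing available here explains the size of these steps.

On these data alone, whether the gain is specific to methoxy remains open, as a hydroxyl, a fluorine or an ethoxy at this place could give a smaller or larger step. Also open, as far as these compounds go, is how a methoxy would behave elsewhere on the phenoxy group.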